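This account rests on a few compounds, and the source may have more. Where it says the series, first, only, none or still open, it means among the compounds named here.

Measured compounds:
compound 1, `CN(C)c1ncnc2c1ncn2Cc1c(F)cccc1Cl`, 5 mg/kg
compound 2, `CC(C)Nc1ncnc2c1ncn2Cc1ccccc1F`, 5.8 mg/kg

Both compounds were tested in a functional assay on the whole organism with Rattus norvegicus as the target, in the maximal electroshock model; on this read-out higher numbers stand for an effect only at larger amounts of compound and lower numbers for an effect already at smaller amounts. Compound 1 gives 5 mg/kg in this assay, and compound 2 gives 5.8 mg/kg. Compound 2 has the higher of the two numbers, but its nearest neighbour is compound 1, and the gap between the two lies within the usual scatter of this kind of measurement, so the two compounds cannot be told apart on these data.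

Compound 3, `Fc1ccccc1Cn1cnc2c(N3CCCC3)ncnc21`, has not yet been measured. It differs from compound 2 in one place: pyrrolidin-1-yl in place of isopropylamino on an aromatic carbon

Within the data shown here, no step between two measured compounds is available to set the scale for this change, so the expectation can rest only on the two values shown, which sit together. Compound 3 is therefore expected to land close to compound 2, with a step of a 1.0-fold higher number from compound 2 to compound 3 (0.01 log units; within the scatter) that is expected to stay within the scatter, in no clear direction. In this assay compound 3 is estimated at 6 mg/kg, with a range from 3 mg/kg to 12 mg/kg.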

Compound 3, dose for half-maximal effect: 12.5 mg/kg
For compound 3 the middle estimate is 2.1-fold (0.32 log units) below the measured one; the whole stated range lies below it.
By their numbers in this assay, from the lowest: compounds 1 and 2 (each within the scatter of the next); then compound 3.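

In this assay, among these compounds, the aromatic carbon next to the ring nitrogen proves sensitive to which amine it carries: pyrrolidin-1-yl in place of isopropylamino gives a 2.2-fold higher number from compound 2 to compound 3 (0.33 log units; beyond the scatter) and so provides the first step that lies beyond the scatter. The step is modest, but it shows that in this pair the pyrrolidin-1-yl compound needs larger amounts for its effect, with the rest of the molecule unchanged. The change closes a five-membered ring and loses the hydrogen-bond donor of isopropylamino at the same time, and nothing available here explains why the number rises.

This single pair cannot separate the effect of the ring from the effect of the lost donor, and cyclopentylamino, which has a ring while keeping the amine hydrogen, would be the group to tell them apart. On these data alone, it also remains open whether a larger ring on the same nitrogen, such as piperidin-1-yl, or a morpholin-4-yl group with its added ring oxygen, would move the number further in the same direction.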